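Piperidinyloxy to cyclobutyloxy on the carboxamide core

This account rests on a few compounds, and the source may have more. Where it says the series, first, only, none or still open, it means among the compounds named here.

Measured so far in an assay on cells for inhibition of MAP kinase-interacting serine/threonine-protein kinase 1 (Homo sapiens), read by mobility shift assay, with stated times of 10 min and 60 min, in the presence of a further agent that is not named here; a lower number here means a stronger inhibitor, a higher number a weaker inhibitor:
compound 1 `NC(=O)c1ccc(-c2cccnc2)cc1OC1CCNCC1` gives 1100 nM
compound 2 `Cc1[nH]ncc1-c1cncc(-c2ccc(C(N)=O)c(OC(C)C)c2)c1` gives 54 nM
compound 3 `CC(C)Oc1cc(-c2cncc(-c3cnn(C)c3)c2)ccc1C(N)=O` gives 400 nM

Compound 1 shows the highest number of the three in this assay; compound 3 sits nearer to it and compound 2 furthest from it, both with lower numbers. Among the compounds with values here, the only step between two compounds that differ in one place runs within the isopropoxy pair: a 7.4-fold higher number from compound 2 to compound 3 (0.87 log units; beyond the scatter). It concerns the substituent on the pyridine side and says nothing about the ether group on the carboxamide core.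

Compound 4 `NC(=O)c1ccc(-c2cccnc2)cc1OC1CCC1` takes the step from compound 1 at the ether: cyclobutyl in place of piperidin-4-yl on an oxygen on an aromatic ring. Within the data shown here, no measured step bears on this change; compounds 2 and 3 carry the isopropyl ether but differ from compound 1 in two places, so their values give no clean read on the ether alone. With nothing to lean on, the expectation for compound 4 is a number near that of compound 1, with a step of a 1.2-fold lower number from compound 1 to compound 4 (0.09 log units; within the scatter) not expected to go beyond the scatter in this assay. The estimate for compound 4 is 900 nM, within a range from 250 nM to 3500 nM.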

Compound 4, half-maximal inhibitory concentration: 1900 nM
Estimate against measurement, compound 4: 2.1-fold (0.32 log units) below, and the stated range covers the measured number.
By their numbers in this assay, from the lowest: compound 2; then compound 3; then compounds 1 and 4 (each within the scatter of the next).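

In this assay, the first read on the ether position of the shared core is a 1.7-fold higher number from compound 1 to compound 4 (0.24 log units; within the scatter), so cyclobutyl and piperidin-4-yl on an oxygen on an aromatic ring are not told apart by this assay. At this level of activity, the ring nitrogen of piperidin-4-yl and its hydrogen-bond donor and acceptor are therefore not required, and a four-membered ring of carbon only serves as well as the six-membered ring with 1 hetero atom. Nothing measured here speaks to why the two groups read alike.

The compounds shown pair the 5-methyl-1H-pyrazol-4-yl and 1-methyl-1H-pyrazol-4-yl groups only with the isopropyl ether, so it remains open whether either group would keep its place in the order on a cyclobutyl or piperidin-4-yl ether. Also open, on these data alone, is whether a longer chain on the same oxygen, such as a 2-aminoethyl chain ending in a primary amine or a chain ending in a carboxylic acid, would separate from the two ring ethers.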